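Trifluoromethyl to hydrogen on two aminothiazole hydrazones

The compounds below may be only part of what the source reports. "The series", "measured", "known", "first", "only" and "open" are said of these compounds alone.

Compound 1 `Fc1ccc(/C=N/Nc2nc(-c3ccc(C(F)(F)F)cc3)cs2)cc1F`: 14600 nM
Compound 2 `Fc1ccc(/C=N/Nc2nc(-c3ccccc3)cs2)cc1F`: 20900 nM
Compound 3 `COc1cc(/C=N/Nc2nc(-c3ccc(C(F)(F)F)cc3)cs2)cc(Br)c1OC`: 65900 nM

Three hydrazone-linked aminothiazoles were examined in a functional assay on Caco-2 cells (Homo sapiens) for inhibition, read by MTT assay, with a stated time of 48 h; a higher number here means a weaker inhibitor, a lower number a stronger inhibitor. Compound 1 gives 14600 nM in this assay, and compound 2 gives 20900 nM. The two differ in one place: hydrogen in place of trifluoromethyl on an aromatic carbon. The step is a 1.4-fold higher number from compound 1 to compound 2 (0.16 log units; within the scatter), so these two compounds cannot be ordered against each other.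

Compound 3 carries a different aryl ring on the hydrazone side, and in this assay compound 3 gives 65900 nM, the highest of the three numbers, beyond the scatter from both others. The difference between the core of compound 3 and the core of compound 1 is not broken down here.

Compound 4 `COc1cc(/C=N/Nc2nc(-c3ccccc3)cs2)cc(Br)c1OC` has not been measured in this assay. It stands to compound 3 as compound 2 stands to compound 1: hydrogen in place of trifluoromethyl on an aromatic carbon. The place is described in the same words in both pairs, so this is the same change made on the other core. The expected step is a 1.4-fold higher number from compound 3 to compound 4 (0.14 log units; within the scatter), resting on the measured pair, because the same change gave a 1.4-fold higher number from compound 1 to compound 2 (0.16 log units; within the scatter). Compound 4 is therefore expected to give about 90000 nM in this assay, most likely between 45000 nM and 180000 nM, with the second core setting the level and the change itself moving the number little.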

Compound 4, half-maximal inhibitory concentration: 64200 nM
Compound 4: middle estimate off by 1.4-fold (0.15 log units), on the high side; the range from low to high includes it.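

In this assay, the same replacement of trifluoromethyl by hydrogen on the second core gives a 1.0-fold lower number from compound 3 to compound 4 (0.01 log units; within the scatter), so these two compounds cannot be ordered against each other. Set beside the earlier step, the result gives no sign that the core alters what this change does: the same change on two cores in this assay, a 1.4-fold higher number (0.16 log units; within the scatter) from compound 1 to compound 2 and a 1.0-fold lower number (0.01 log units; within the scatter) from compound 3 to compound 4, 1.5-fold (0.17 log units) apart, within the scatter of two such steps. Within these two pairs, the change can therefore be carried from one core to the other with no shift in the number beyond the scatter, but this rests on only two cores and one assay, and neither pair separates the two groups, so it does not show that trifluoromethyl would be equally dispensable on other cores or in other assays.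

The compounds shown leave open whether a different group in the same place, such as a nitrile, an amine or a carboxylic acid, would move the number beyond the scatter on either core. They also leave open how much the bromine and each methoxy group on the aryl ring of the second core contribute on their own, since these groups occur only together here.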